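Methyl on the saturated ring of a weak thiazole-quinazoline amide

A few compounds are considered here, and "the series" means these few. Any claim that something is new, unique, unknown or untested is made for them only; others in the source may bear on it.

Compound 1 `COc1cc2c(Nc3nc4ccc(C(=O)Nc5c(C)cccc5C)cc4s3)ncnc2cc1OCCCN1CCCCC1` sits at the top of the set: in a functional assay on DLD-1 cells (Homo sapiens) for cytotoxicity, read by WST assay, with a stated time of 72 h (on this read-out lower numbers stand for stronger inhibition and higher numbers for weaker inhibition), compound 1 gives only a limit, > 100000 nM, and no number. Its neighbours change the aryl amide end. Compound 2 `COc1cc2c(Nc3nc4ccc(C(=O)Nc5c(C)cc(C)cc5C)cc4s3)ncnc2cc1OCCCN1CCCCC1` gives 24500 nM, and compound 3 `COc1cc2c(Nc3nc4ccc(C(=O)Nc5c(C)cccc5Cl)cc4s3)ncnc2cc1OCCCN1CCCCC1` gives 14700 nM. The step of an at least 4.0-fold lower number from compound 1 to compound 2 (0.61 log units; beyond the scatter) and the step of an at least 6.8-fold lower number from compound 1 to compound 3 (0.83 log units; beyond the scatter) both run from a limit, so each is only a lower bound (the limit of > 100000 nM in this assay, at which 1 of the 3 values shown sits); the step of a 1.7-fold lower number from compound 2 to compound 3 (0.22 log units; within the scatter) lies within the scatter.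

Compound 4 `COc1cc2c(Nc3nc4ccc(C(=O)Nc5c(C)cccc5C)cc4s3)ncnc2cc1OCCCN1CCCCC1C` keeps the aryl amide of compound 1 and differs only on the other end: methyl in place of hydrogen on a saturated ring carbon. For the measured compounds named here, none of the three measured steps touches this saturated ring; all of them alter the aryl amide, so no measured step bears on the change, and no direction can be read from the series. The expected step is therefore a step that the limit leaves unreadable from compound 1 to compound 4, none beyond the scatter, with the value most likely again reported as a limit. For compound 4 the estimate in this assay is 150000 nM, expected between 40000 nM and 600000 nM.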

Compound 4, half-maximal inhibitory concentration: > 100000 nM
Compound 4: a limit, no number (the forecaster's own chance of this, stated with the estimate: 70%); the middle value does not contradict the limit.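

In this assay compound 4 gives > 100000 nM, which is a limit and not a number. Compound 1 also stands at a limit, so no step can be read between compound 1 and compound 4: the limit of > 100000 nM in this assay, at which 2 of the 4 values shown sit.

The compounds shown leave open what 2-methylpiperidin-1-yl in place of piperidin-1-yl does to the read-out where both partners carry a measured number.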